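The compounds below may be only part of what the source reports. "The series", "measured", "known", "first", "only" and "open" are said of these compounds alone.

- Compound 1 `O=C(O)CCCCCCC(=O)Nc1ccc(C2=C(c3ccc(O)cc3)C3CC(S(=O)(=O)Oc4ccccc4C(F)(F)F)C2O3)cc1`: > 100000 nM
- Compound 2 `O=S(=O)(Oc1ccccc1)[C@H]1C[C@H]2O[C@@H]1C(c1ccc(O)cc1)=C2c1ccc(O)cc1`: > 100000 nM

In an ADME assay on Vero cells (Chlorocebus sabaeus) for inhibition, read by MTT assay, with a stated time of 72 h (on this read-out higher numbers stand for weaker inhibition and lower numbers for stronger inhibition), compound 1 gives > 100000 nM, which is a limit of the assay and not a number. Compound 2 gives > 100000 nM, which is likewise a limit. Within the data shown here, neither compound therefore has a number of its own, and the data show no measured step between compounds.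

Compound 3 `O=C(O)CCCCCCC(=O)Nc1ccc(C2=C(c3ccc(O)cc3)C3CC(S(=O)(=O)Oc4cccc5ccccc45)C2O3)cc1` has not yet been measured. It keeps the rest of compound 1 and changes one group: naphthalen-1-yl in place of 2-(trifluoromethyl)phenyl on an oxygen. Naphthalen-1-yl takes the place of 2-(trifluoromethyl)phenyl on an oxygen whose other neighbour is the sulfonyl sulfur.

The expectation rests on (the limit of > 100000 nM in this assay, at which 2 of the 2 values shown sit). The expected step of a number no higher from compound 1 to compound 3 (the limit leaves the size open) stays within the scatter, with no direction foreseen, and a further limit is the likeliest report. For compound 3 the estimated value is 100000 nM, with an expected range of 30000 nM to 200000 nM.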

Compound 3, half-maximal inhibitory concentration: > 100000 nM
Compound 3 was reported as a limit (the forecaster's own chance of this, stated with the estimate: 80%); the middle value sits exactly at the limit.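

In this assay compound 3 gives > 100000 nM, which is a limit of the assay and not a number. Compound 1 also stands at a limit, and the step between the two cannot be read. The compounds shown leave open whether exchanging 2-(trifluoromethyl)phenyl for naphthalen-1-yl changes inhibition in this assay at all.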